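A few compounds are considered here, and "the series" means these few. Any claim that something is new, unique, unknown or untested is made for them only; others in the source may bear on it.

Measured compounds, in a functional assay on CHO-K1 cells for antagonist activity at transient receptor potential cation channel subfamily V member 1 (Homo sapiens), read by FLIPR; a higher number here means a weaker inhibitor, a lower number a stronger inhibitor:
compound 1 `CC(C(=O)NCc1ccc(C(F)(F)F)nc1NC1CCCCC1)c1ccc(NS(C)(=O)=O)c(F)c1`, 20.4 nM
compound 2 `CC(C(=O)NCc1ccc(C(F)(F)F)nc1N(C)C)c1ccc(NS(C)(=O)=O)c(F)c1`, 19.1 nM
compound 3 `CCCN(CCC)c1nc(C(F)(F)F)ccc1CNC(=O)C(C)c1ccc(NS(C)(=O)=O)c(F)c1`, 0.2 nM

Compound 3 gives the lowest number of the three; the gaps are a 96-fold lower number from compound 2 to compound 3 (1.98 log units; beyond the scatter) and a 100-fold lower number from compound 1 to compound 3 (2.01 log units; beyond the scatter), both large. Compound 1 and compound 2 are within the scatter of each other, a 1.1-fold lower number from compound 1 to compound 2 (0.03 log units; within the scatter).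

Compound 4 `CC(C(=O)NCc1ccc(C(F)(F)F)nc1N1CC=CCC1)c1ccc(NS(C)(=O)=O)c(F)c1` carries the change (a group of 6 heavy atoms (5 carbon, 1 nitrogen; one six-membered non-aromatic ring with 1 hetero atom) in place of a group of 7 heavy atoms (6 carbon, 1 nitrogen; no ring), on an aromatic carbon). Both shown steps into compound 3 bear on this, as each swaps the amine on that aromatic carbon, and both were large; the incoming group shares the ring of compound 1 and the tertiary nitrogen of compound 3, so the step of a 10-fold higher number from compound 3 to compound 4 (1.00 log units; beyond the scatter) is expected to lose part of that gain. Compound 4 is estimated at 2 nM, range 0.3 nM to 15 nM.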

Compound 4, inhibition constant: 0.3 nM
Compound 4: middle estimate off by 6.7-fold (0.82 log units), on the high side; low and high end bracket the measured number.
By their numbers in this assay, from the lowest: compounds 3 and 4 (each within the scatter of the next); then compounds 2 and 1 (each within the scatter of the next).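

The open dipropylamino chains are not required on this aromatic carbon: the step of a 1.5-fold higher number from compound 3 to compound 4 (0.18 log units; within the scatter) stays within the scatter, so a six-membered non-aromatic ring with 1 hetero atom serves equally well. The large steps of a 64-fold lower number from compound 2 to compound 4 (1.80 log units; beyond the scatter) and a 68-fold lower number from compound 1 to compound 4 (1.83 log units; beyond the scatter) place this ring with dipropylamino, well apart from dimethylamino and cyclohexylamino. No measurement shown accounts for these steps. Open, as far as these compounds go, is what the ring's double bond contributes, since a saturated piperidine would be needed to test it. Also open, from the compounds shown here alone, is how a morpholine or diethylamino would fare here.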